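This account rests on a few compounds, and the source may have more. Where it says the series, first, only, none or still open, it means among the compounds named here.

Working notes on the series. Three compounds have numbers in a functional assay on cells (Leukemia cell, Homo sapiens) for cytotoxicity, with a stated time of 48 h; a higher number here means a weaker inhibitor of growth, a lower number a stronger inhibitor of growth. Compound 1 `COc1cc2c(/C=C3/C(=O)Nc4ccc(O)cc43)c(Cl)n(Cc3cc(OC)c(OC)c(OC)c3)c2cc1C` gives 18600 nM and stands second highest of the three; compound 2 `O=C1Nc2ccccc2/C1=C\c1c(Cl)n(Cc2ccccc2)c2ccccc12` gives 21400 nM, a difference from compound 1 that lies within the scatter, while compound 3 `COc1c(/C=C2/C(=O)Nc3ccccc32)c2ccccc2n1-c1ccccc1` gives 2630 nM, a lower number than compound 1 that lies beyond the scatter. Compound 4 `COc1ccc2c(c1)/C(=C\c1c(Cl)n(Cc3cc(OC)c(OC)c(OC)c3)c3cc(C)c(OC)cc13)C(=O)N2` is not yet measured. It differs from compound 1 by methyl in place of hydrogen on an oxygen on an aromatic ring, a change that keeps the rest of the core of compound 1 intact. Among the measured compounds shown here, no measured pair in this set isolates that change, so the expectation rests on compound 1 alone: no step beyond the scatter is expected, and the step from a 1.2-fold lower number from compound 1 to compound 4 (0.09 log units; within the scatter) is estimated as small in either direction. Compound 4 is therefore expected to give about 15000 nM in this assay, with a range from 5000 nM to 45000 nM.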

Compound 4, concentration for total growth inhibition: 77600 nM
Compound 4: middle estimate off by 5.2-fold (0.71 log units), on the low side; the whole stated range lies below it.
By their numbers in this assay, from the lowest: compound 3; then compounds 1 and 2 (each within the scatter of the next); then compound 4.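

Hydroxy to methoxy on the aromatic ring is the first single change that can be read in the series. In this assay it gives a 4.2-fold higher number from compound 1 to compound 4 (0.62 log units; beyond the scatter), so this oxygen is not indifferent to methyl in place of hydrogen, and the methoxy compound is the weaker inhibitor of growth of the pair. Nothing measured here bears on the cause of this step.

Still open, from the compounds shown here alone, is whether an amine or a longer chain on this oxygen would move the number further. Also open, going by these compounds, is whether the step carries over to a core other than that of compound 1.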